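Carbamate variation on the prenylated core

The source may report more compounds than this note shows. Statements on the series, on what has been measured and on what is new or still open speak of the compounds shown alone.

Measured so far:
compound 1 `CCOc1cc(=O)n(CCCO)c2c1CC(CC=C(C)C)C(C)(C)C2`: 66.5%
compound 2 `CC(C)=CCC1Cc2c(OC(=O)Nc3ccc(F)cc3)cc(=O)n(CCCO)c2CC1(C)C`: 71.2%

In a functional assay on PANC-1 cells (Homo sapiens) for inhibition, read by MTT assay, with a stated time of 24 h, tested at 10 uM (on this read-out higher numbers stand for more inhibition at the one concentration tested (going by the name of the read-out) and lower numbers for less inhibition), compound 1 gives 66.5% and compound 2 gives 71.2%. The two stand together, since the step of a number 4.7 percentage points higher from compound 1 to compound 2 (within the scatter) lies within the scatter, so neither is set apart from the other. Compound 3 `CC(C)=CCC1Cc2c(OC(=O)Nc3ccc(Cl)c(Cl)c3)cc(=O)n(CCCO)c2CC1(C)C` differs from compound 2 by 3,4-dichlorophenyl in place of 4-fluorophenyl on an amide-type nitrogen. Among the measured compounds shown here, the only measured step concerns another place, on an oxygen on an aromatic ring, and is itself within the scatter, so nothing among the measured compounds speaks for a shift beyond the scatter in this assay from this exchange. For compound 3 the expected value is 70%, in the range 55% to 85%. The step this estimate means, a number 1.2 percentage points lower from compound 2 to compound 3 (within the scatter), is expected to stay within the scatter.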

Compound 3, a percentage reported as inhibition, at one concentration (the size of the read-out at that concentration, not a potency): 61.4%
The estimate for compound 3 lay 8.6 percentage points above the measured number, within the range that was stated.
By their numbers in this assay, from the lowest: compounds 3, 1 and 2 (each within the scatter of the next).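

In this assay, 3,4-dichlorophenyl in place of 4-fluorophenyl on the amide-type nitrogen gives a number 9.8 percentage points lower from compound 2 to compound 3 (within the scatter) and so shows that this position accepts the exchange without a shift beyond the scatter. (3,4-Dichlorophenyl)carbamoyl in place of ethyl on the oxygen gives a number 5.1 percentage points lower from compound 1 to compound 3 (within the scatter) and so leaves this carbamate level with compound 1 as well. Nothing available explains these numbers. As far as these compounds go, whether a carboxylic acid or a dimethylamino group on the phenyl ring, or a longer alkyl chain in its place on the nitrogen, would move the number beyond the scatter remains open.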